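The compounds below may be only part of what the source reports. "The series", "measured", "known", "first", "only" and "open" are said of these compounds alone.

The series shares one core, shown for compound 1 `COC(=O)c1ccc(OCCCCOc2ccc(C(=O)CC3CCCC3)c(O)c2C)cc1`, in which a four-carbon chain joins two aromatic pieces. In an assay on HEK293 cells for positive allosteric modulation of metabotropic glutamate receptor 2 (Rattus norvegicus), read by thallium flux, with a stated time of 2.5 min (on this read-out lower numbers stand for an effect already at smaller amounts and higher numbers for an effect only at larger amounts of compound), compound 1 gives "not determined" (no result reported). Compound 2 `Cc1c(OCCCCOc2ccc(C(=O)O)cc2F)ccc(C(=O)CC2CCCC2)c1O` carries a free acid and a fluorine on the far ring, and in this assay compound 2 gives 639 nM. Going by the values given here, compound 3 `COC(=O)c1ccc(OCCCCOc2ccc(C(=O)CC(C)C)c(O)c2C)cc1` keeps the methyl ester of compound 1 with a shorter ketone side chain; in this assay compound 3 gives "not determined" (no result reported), so compound 3 stands without a number, as does compound 1, and no step between measured compounds can be drawn from it. Compound 4 `Cc1c(OCCCCOc2ccc(C(=O)O)c(Cl)c2)ccc(C(=O)CC(C)C)c1O` differs from compound 3 by 4-carboxy-3-chlorophenyl in place of 4-(methoxycarbonyl)phenyl on an oxygen on a saturated carbon. Among the compounds with values here, with no measured step available, the size of this change cannot be read off; the only anchor is compound 2, whose value of 639 nM comes from a closely related acid, so compound 4 is expected to land near that mark rather than clearly beyond the scatter in either direction. Compound 4 is therefore estimated at about 900 nM, with a range from 200 nM to 4000 nM.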

Compound 4, half-maximal effective concentration: 151 nM
The estimate for compound 4 lay 6.0-fold (0.78 log units) above the measured number; the measured number lies below the stated range.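

Going by these compounds alone, compound 3 stands without a single number in this assay, and no step to compound 4 can be read. The compounds shown leave open how far 4-carboxy-3-chlorophenyl in place of 4-(methoxycarbonyl)phenyl alone moves the read-out. No evidence bearing on this result is available.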